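Ester chain extension on the platelet-activating factor series

A few compounds are considered here, and "the series" means these few. Any claim that something is new, unique, unknown or untested is made for them only; others in the source may bear on it.

Compound 3 `CC(=O)OC[C@H]1[C@H]2CC[C@@H](C)[C@]1(C)CC/C(C)=C/CC[C@@]1(C)O[C@@H]1[C@@H]2O` gives 80 nM in an assay (Oryctolagus cuniculus) for inhibition of platelet-activating factor receptor (Cavia porcellus) (a higher number here means a weaker inhibitor, a lower number a stronger inhibitor), the lowest of the three numbers; compound 2 `C/C1=C\CC[C@@]2(C)O[C@@H]2C(=O)[C@@H]2CC[C@@H](C)[C@](C)(CC1)[C@H]2COC(=O)N(C)C` gives 180 nM and compound 1 `CC(=O)OC[C@H]1[C@H]2CC[C@@H](C)[C@]1(C)CC/C(C)=C/CC[C@@]1(C)O[C@@H]1C2=O` gives 410 nM. Compound 4 `CCC(=O)OC[C@H]1[C@H]2CC[C@@H](C)[C@]1(C)CC/C(C)=C/CC[C@@]1(C)O[C@@H]1[C@@H]2O` differs from compound 3 by methyl in place of hydrogen on a saturated chain carbon bound to a carbonyl carbon. Going by the values given here, the only measured step at the ester, a 2.3-fold lower number from compound 1 to compound 2 (0.36 log units; beyond the scatter), swaps in a dimethylamino group on a scaffold carrying a ketone where compound 3 carries an alcohol, so it bears only loosely on the present change, and no pair among the measured compounds isolates a pure chain extension. The change is expected to leave the number close to that of compound 3, the step of a 1.1-fold lower number from compound 3 to compound 4 (0.03 log units; within the scatter) anticipated to stay within the scatter. Compound 4 is therefore estimated at 75 nM, with a range of 30 nM to 190 nM in this assay.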

Compound 4, half-maximal inhibitory concentration: 340 nM
For compound 4 the middle estimate is 4.5-fold (0.66 log units) below the measured one; the whole stated range lies below it.
By their numbers in this assay, from the lowest: compound 3; then compounds 2, 4 and 1 (each within the scatter of the next, the first and the last beyond it).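

Extension at this ester is not neutral: acetoxy to propanoyloxy, with methyl in place of hydrogen on a saturated chain carbon bound to a carbonyl carbon, gives a 4.3-fold higher number from compound 3 to compound 4 (0.63 log units; beyond the scatter) in this assay. Going by these compounds alone, this is the first measured change confined to the ester chain on a single core, and it shows that this position responds to the addition of a single methyl. Acetoxy remains the better of the two esters on the core of compound 3.

On these data alone, whether a longer chain such as butanoyloxy, or an amine on the chain, would move the number further remains open. Nothing available accounts for the size of this step.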